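From a hydroxy group to (2-fluorobenzyl)oxy

The compounds below may be only part of what the source reports. "The series", "measured", "known", "first", "only" and "open" are said of these compounds alone.

Compound 1 (`O=S(=O)(c1cccc(-c2ccc3ncnc(Nc4ccc(OCc5cccc(F)c5)c(Cl)c4)c3c2)c1)N1CCOCC1`) gives > 15000 nM in an ADME assay on HepG2 cells (Homo sapiens) for cytotoxicity, read by MTT assay, with a stated time of 48 h (on this read-out lower numbers stand for stronger inhibition and higher numbers for weaker inhibition), as a limit of the assay, not a number. Compound 2 (`O=S(=O)(c1ccc(-c2ccc3ncnc(Nc4ccc(O)c(Cl)c4)c3c2)cc1)N1CCOCC1`) gives > 15000 nM in this assay as a limit too. Compound 2 therefore stands at the limit of > 15000 nM in this assay, at which 2 of the 2 values shown sit, and has no exact number. Compound 3 (`O=S(=O)(c1ccc(-c2ccc3ncnc(Nc4ccc(OCc5ccccc5F)c(Cl)c4)c3c2)cc1)N1CCOCC1`) carries 2-fluorobenzyl in place of hydrogen on an oxygen on an aromatic ring. Among the measured compounds shown here, no measured step shows what such a change does. Compound 1 also bears a fluorobenzyl group on an oxygen, and its result is the limit > 15000 nM in this assay once more. No change beyond the usual scatter is therefore expected, in either direction. The expected move is a step that the limit leaves unreadable from compound 2 to compound 3 on this one comparison. Compound 3 is estimated at 20000 nM within an expected range from 8000 nM to 50000 nM and will probably return only a limit.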

Compound 3, half-maximal inhibitory concentration: > 15000 nM
Compound 3 was reported as a limit (the forecaster's own chance of this, stated with the estimate: 80%); the middle value is on the limit's open side.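

No step from compound 2 to compound 3 can be read in this assay, since both results are limits of the assay and not numbers: the limit of > 15000 nM in this assay, at which 3 of the 3 values shown sit.

The compounds shown leave open whether 2-fluorobenzyl in place of hydrogen on that oxygen changes the true inhibitory concentration at all, and what that concentration is for compound 1, compound 2 or compound 3.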